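Exchanging the Amine at the End of a Shared Chain

The source may report more compounds than this note shows. Statements on the series, on what has been measured and on what is new or still open speak of the compounds shown alone.

Compound 3 `COc1cc(OC)c2c(=O)cc(-c3ccc(OCC(O)CN4CCCC4)cc3)oc2c1` gives 57% in a functional assay (Homo sapiens) for antiproliferative activity, read by resazurin assay, with a stated time of 48 h, tested at 20 uM (a lower number here means a weaker effect, a higher number a stronger effect of the compound at the concentration tested), the highest of the two numbers recorded. Compound 1 `COc1cc(OC)c2c(=O)cc(-c3ccc(OCCF)cc3)oc2c1` gives 21% in this assay, and the step of a number 36 percentage points higher from compound 1 to compound 3 (beyond the scatter) lies beyond the scatter. Compound 2 `COc1cc(OC)c2c(=O)cc(-c3ccc(OC4CCN(C)CC4)cc3)oc2c1` gives "not determined" (no result reported) in this assay, so no number is available for it. Compound 4 `COc1cc(OC)c2c(=O)cc(-c3ccc(OCC(O)CN(C)C)cc3)oc2c1` differs from compound 3 in one place: dimethylamino in place of pyrrolidin-1-yl on a saturated chain carbon, two bonds along the chain from an oxygen on a saturated carbon. For the measured compounds named here, no measured step exchanges one amine for another; the single step recorded, from compound 1 to compound 3, installs the whole hydroxy-amine chain at once and does not show how much the amine's ring contributes on its own. The chain itself stays in place in compound 4. Only a modest step is expected, a number 7 percentage points lower from compound 3 to compound 4 (within the scatter), and it may well stay within the scatter. Compound 4 is therefore estimated at 50%, with a range from 30% to 70%.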

Compound 4, a percentage reported as inhibition, at one concentration (the size of the read-out at that concentration, not a potency): 71%
Beside the measured number, compound 4's estimate is 21 percentage points below it; the whole stated range lies below it.
By their numbers in this assay, from the lowest: compound 1; then compound 3; then compound 4.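

The amine at the end of the chain matters on its own: in this assay, dimethylamino in place of pyrrolidin-1-yl gives a number 14 percentage points higher from compound 3 to compound 4 (beyond the scatter) with the rest of the molecule unchanged. A ring on the amine is therefore not needed for this chain to work, and 2-(dimethylamino)-1-hydroxyethyl in place of fluoromethyl gives a number 50 percentage points higher from compound 1 to compound 4 (beyond the scatter) in the same test. No available evidence explains this difference between the two amines. On these data alone, whether diethylamino or morpholin-4-yl would continue this trend remains open. The compounds shown also do not separate the contribution of the chain's hydroxy group from that of its amine.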